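The source may report more compounds than this note shows. Statements on the series, on what has been measured and on what is new or still open speak of the compounds shown alone.

Working notes on the series in an ADME assay on HEK293 cells (Homo sapiens) for cytotoxicity, read by resazurin assay, with a stated time of 48 h; on this read-out higher numbers stand for lower toxicity in this test and lower numbers for higher toxicity in this test. Compound 1 `O=S(=O)(Nc1ccc(-c2nc3ccccc3o2)cc1)c1ccccc1Cl` gives > 100000 nM, which is a limit of the assay. Among the measured compounds shown here, compound 2 `CCc1ccc(S(=O)(=O)Nc2ccc(-c3nc4ccccc4o3)cc2)cc1` gives 82000 nM, the only actual number so far. Compound 3 `COc1ccc(S(=O)(=O)Nc2ccc(-c3nc4ccccc4o3)cc2)cc1` gives > 100000 nM, which is also a limit. Compound 3 therefore stands at the limit of > 100000 nM in this assay, at which 2 of the 3 values shown sit.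

Compound 4 `Cc1cccc(S(=O)(=O)Nc2ccc(-c3nc4ccccc4o3)cc2)c1` carries 3-methylphenyl in place of 4-methoxyphenyl on a sulfonyl sulfur.

Three measured swaps on that sulfur bear on this change. One is an at least 1.2-fold lower number from compound 1 to compound 2 (0.08 log units; that floor lies within the scatter). Another is an at least 1.2-fold higher number from compound 2 to compound 3 (0.08 log units; that floor lies within the scatter). The third is a step that the two limits leave unreadable from compound 1 to compound 3. Neither readable step shows a size beyond the scatter, so none beyond the scatter is expected in this assay. For the measured compounds named here, the expectation leans on compound 2 at 82000 nM, the one number available. A report of only a limit for compound 4 would be no surprise.

The expected step is an at least 1.0-fold lower number from compound 3 to compound 4 (0.03 log units; that floor lies within the scatter). For compound 4 the estimated value is 92000 nM, with an expected range of 50000 nM to 170000 nM.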

Compound 4, half-maximal cytotoxic concentration: > 100000 nM
Compound 4 was reported as a limit; the forecaster's own chance of this, stated with the estimate: 50%; at least 1.0-fold (0.03 log units) between middle value and limit.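

In this assay, compound 4 is reported only as a limit, so a substituent without the hydrogen-bond acceptor of 4-methoxyphenyl sits at the same limit, and three different aryl groups on the sulfonyl sulfur now do so: the limit of > 100000 nM in this assay, at which 3 of the 4 values shown sit. Among the compounds shown here, the one group that gives a number, the 4-ethylphenyl of compound 2, goes against that pattern, yet an at least 1.2-fold higher number from compound 2 to compound 4 (0.08 log units; that floor lies within the scatter), so the series shows no separation from compound 2 beyond the scatter. The steps linking compound 4 to compound 1 and compound 3 cannot be read, since both ends of each are limits.

As far as these compounds go, how far these limit compounds lie from one another stays unknown. Also open, from the compounds shown here alone, is whether an amine or a carboxylic acid on this aromatic ring, or a longer chain in its place, would give a number clearly lower in this test.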